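The compounds below may be only part of what the source reports. "The series", "measured", "known", "first", "only" and "open" are said of these compounds alone.

Measured compounds:
- compound 1 `Cc1cccc(NC(=O)N[C@H](C)c2ccccc2)c1`: 100%
- compound 2 `CC(=O)c1cccc(NC(=O)N[C@H](C)c2ccccc2)c1`: 98%

In an ADME assay on the whole organism with Oryza sativa as the target, tested at 0.1 uM (a lower number here means a stronger effect, a higher number a weaker effect of the compound at the concentration tested), compound 2 gives 98% and stands as the lower of the two numbers, with compound 1 at 100% nearest, the two lying within the scatter. Going by the values given here, the one measured step, a number 2 percentage points lower from compound 1 to compound 2 (within the scatter), also stays within the scatter. Compound 3 `C[C@@H](NC(=O)Nc1cccc(I)c1)c1ccccc1` is not yet measured; it differs from compound 2 by iodo in place of acetyl on an aromatic carbon at the same aromatic carbon. Among the compounds with values here, only the step from compound 1 to compound 2 bears on this exchange, and it was flat, so no movement beyond the scatter is expected in this assay: the expected step is a number 1 percentage points lower from compound 2 to compound 3 (within the scatter). Compound 3 is therefore estimated at 97%, ranging from 85% to 100%.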

Compound 3, a percentage reported as activity, at one concentration (the size of the read-out at that concentration, not a potency): 81%
For compound 3 the middle estimate is 16 percentage points above the measured one, and the stated range ends above it.
By their numbers in this assay, from the lowest: compound 3; then compounds 2 and 1 (each within the scatter of the next).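

At the aromatic carbon meta to a large group, the number in this assay does respond to the substituent: iodo in place of acetyl gives a number 17 percentage points lower from compound 2 to compound 3 (beyond the scatter) and iodo in place of methyl gives a number 19 percentage points lower from compound 1 to compound 3 (beyond the scatter). The earlier exchange of methyl for acetyl showed no such movement, so of the three groups, iodo alone separates from the others. Nothing at hand accounts for this shift. Open, as far as these compounds go, is whether bromo or chloro at this carbon would follow iodo, and how an amine or a carboxylic acid there would read.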